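Ethyl to isopropyl on a shared prostanoid receptor scaffold

The source may hold more compounds than are shown below. What is called first, only, known or untested is meant among the compounds shown, and "the series" means these compounds.

Of the compounds shown here, three built on one shared core have been tested in an assay on membranes from Chem-1 cells for displacement of a labelled ligand from prostaglandin E2 receptor EP3 subtype (Homo sapiens), read by scintillation counting, with a stated time of 2 h; on this read-out higher numbers stand for weaker inhibition and lower numbers for stronger inhibition. Compound 1 `CC(C)[C@@H](c1ccc(-c2ccc3cccc(F)c3c2)[nH]c1=O)[C@H]1OC(=O)NC1=O` gives 27 nM, compound 2 `O=C1NC(=O)/C(=C/C(Cc2ccccc2)c2ccc(-c3ccc4cccc(F)c4c3)[nH]c2=O)O1` gives 33 nM, and compound 3 `CCc1cccc2ccc(-c3ccc(C(/C=C4\OC(=O)NC4=O)(CC)CC)c(=O)[nH]3)cc12` gives 17 nM. Compound 3 shows the smallest of the three numbers, yet its gaps to compound 1 and to compound 2 both lie within the scatter of this assay, so the three are not separated.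

Compound 4 `CCC(/C=C1\OC(=O)NC1=O)(CC)c1ccc(-c2ccc3cccc(C(C)C)c3c2)[nH]c1=O` is the next candidate. It differs from compound 3 by methyl in place of hydrogen on a saturated chain carbon bound to an aromatic carbon and a saturated chain carbon. Among the compounds with values here, with no measured pair carrying this change, the step from compound 3 to compound 4 is expected to stay within the scatter, as a 1.2-fold higher number from compound 3 to compound 4 (0.07 log units; within the scatter) states. Compound 4 is accordingly estimated at 20 nM, within a range from 8 nM to 50 nM.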

Compound 4, inhibition constant: 120 nM
Beside the measured number, compound 4's estimate is 6.0-fold (0.78 log units) below it; the measured number lies above the stated range.
By their numbers in this assay, from the lowest: compounds 3, 1 and 2 (each within the scatter of the next); then compound 4.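

In this assay the change from ethyl to isopropyl gives a 7.1-fold higher number from compound 3 to compound 4 (0.85 log units; beyond the scatter), the only difference here that lies beyond the scatter. Among these compounds, this saturated chain carbon bound to an aromatic carbon and a saturated chain carbon is therefore a place where one added methyl weakens inhibition measurably, whereas the earlier numbers separated nothing. No measurement shown here accounts for this step.

The compounds shown leave open how a methoxy group or a longer chain, such as propyl, would read at this place. They also leave open whether a smaller group, such as methyl, would hold the number of the ethyl compound.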